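The source may hold more compounds than are shown below. What is called first, only, known or untested is meant among the compounds shown, and "the series" means these compounds.

Measured compounds in the series:

compound 1 `O=C(O)CCc1ccc(NC(=O)c2nnc(COc3ccc4c(c3)CCC4)s2)cc1` — 1380 nM
compound 2 `O=C(O)CCc1ccc(NC(=O)c2nnc(COc3cccc(Cl)c3)s2)cc1` — 1570 nM
compound 3 `Cc1ccc(OCc2nnc(C(=O)Nc3ccc(CCC(=O)O)cc3)s2)cc1C` — 1130 nM

All three share the same core and differ only in the aryl group on an oxygen on a saturated carbon. In a functional assay on CHO cells for agonist activity at Free fatty acid receptor 1 (Homo sapiens), read by FLIPR and calcium flux, tested at 1 uM (on this read-out higher numbers stand for an effect only at larger amounts of compound and lower numbers for an effect already at smaller amounts), compound 3 holds the lowest number of the three, but none of the steps separating it from the others is beyond the scatter: a 1.2-fold lower number from compound 1 to compound 3 (0.09 log units; within the scatter) and a 1.4-fold lower number from compound 2 to compound 3 (0.14 log units; within the scatter). The remaining pair is likewise flat, a 1.1-fold higher number from compound 1 to compound 2 (0.06 log units; within the scatter). On the numbers shown, the three aryl groups are not distinguishable.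

Compound 4 `O=C(O)CCc1ccc(NC(=O)c2nnc(COc3cccc(C(F)(F)F)c3)s2)cc1` is not yet measured. Its change from compound 3 is 3-(trifluoromethyl)phenyl in place of 3,4-dimethylphenyl on an oxygen on a saturated carbon. For the measured compounds named here, the steps that bear on it are those exchanging one aryl group for another at this same oxygen, above all the step from a 3-chlorophenyl to a 3,4-dimethylphenyl, a 1.4-fold lower number from compound 2 to compound 3 (0.14 log units; within the scatter), and the step from the 2,3-dihydro-1H-inden-5-yl, a 1.2-fold lower number from compound 1 to compound 3 (0.09 log units; within the scatter). Each was within the scatter, so for the step to a 3-(trifluoromethyl)phenyl no movement beyond the scatter is expected in this assay, in either direction; the expected step is a 1.3-fold higher number from compound 3 to compound 4 (0.12 log units; within the scatter). Compound 4 is therefore estimated at 1500 nM, with a range from 700 nM to 3200 nM.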

Compound 4, half-maximal effective concentration: 3090 nM
Estimate against measurement, compound 4: 2.1-fold (0.31 log units) below, within the range that was stated.
By their numbers in this assay, from the lowest: compounds 3, 1, 2 and 4 (each within the scatter of the next, the first and the last beyond it).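

In this assay, for the compounds shown here, the aryl group on an oxygen on a saturated carbon no longer looks flat, since a 2.7-fold higher number from compound 3 to compound 4 (0.44 log units; beyond the scatter) and a 2.2-fold higher number from compound 1 to compound 4 (0.35 log units; beyond the scatter) are the first steps at this position to pass the scatter, both of them modest. The closest exchange, trifluoromethyl in place of chloro on an aromatic carbon, stays inside the scatter at a 2.0-fold higher number from compound 2 to compound 4 (0.29 log units; within the scatter) and leaves compound 4 not distinguishable from compound 2. The series therefore does not split into separate groups: compound 2 lies within the scatter of both compound 3 and compound 4, and the 3-(trifluoromethyl)phenyl group stands apart only when set against the 3,4-dimethylphenyl and 2,3-dihydro-1H-inden-5-yl groups.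

No measurement in hand bears on the origin of this shift. Still open, on these data alone, is whether an amine, a nitrile or a methoxy group on the same aryl ring, or a longer chain in place of the aryl group, would bring a number clearly lower than those of compound 1, compound 2 and compound 3, which so far cannot be told apart.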